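A Ring Nitrogen Swap on the Amide-Linked Bicycle

This account rests on a few compounds, and the source may have more. Where it says the series, first, only, none or still open, it means among the compounds named here.

Compound 3 `CCOc1ncc(-c2nc(C(F)(F)F)sc2N2CCN(C(=O)Cn3ccc4cccnc43)[C@H](C)C2)cn1` stands lowest of the three numbers in an assay on blood for inhibition of C-X-C chemokine receptor type 3 (Homo sapiens), with a stated time of 30 min (a higher number here means a weaker inhibitor, a lower number a stronger inhibitor), where compound 3 gives 47 nM. Its nearest neighbour is compound 2 `CCOc1ncc(-c2nc(C(F)(F)F)sc2N2CCN(C(=O)Cn3cnc4ccccc43)[C@H](C)C2)cn1`, which in this assay gives 192 nM, and the furthest is compound 1 `C[C@@H]1CN(c2scnc2-c2nc3ccccc3[nH]2)CCN1C(=O)Cn1cnc2cccnc21`, which in this assay gives 554 nM. Among the measured compounds shown here, the one step measured in one place is a 4.1-fold lower number from compound 2 to compound 3 (0.61 log units; beyond the scatter), a modest but clear gain from one bicyclic group to another on the saturated chain carbon bound to the carbonyl carbon.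

Compound 4 `CCOc1ncc(-c2nc(C(F)(F)F)sc2N2CCN(C(=O)Cn3ncc4cccnc43)[C@H](C)C2)cn1` differs from compound 3 at the same position: a group of 9 heavy atoms (6 carbon, 3 nitrogen; one five-membered aromatic ring with 2 hetero atoms, one six-membered aromatic ring with 1 hetero atom) in place of a group of 9 heavy atoms (7 carbon, 2 nitrogen; one five-membered aromatic ring with 1 hetero atom, one six-membered aromatic ring with 1 hetero atom), on a saturated chain carbon bound to a carbonyl carbon. For the measured compounds named here, this is not the same exchange as the one from compound 2 to compound 3, so no measured step bears on it directly; the only guidance is that the bicycle at this position has moved the number by a modest amount before. With a change confined to one ring atom within the same bicyclic shape, compound 4 is expected to stay close to compound 3, with a step of a 1.5-fold higher number from compound 3 to compound 4 (0.17 log units; within the scatter) that may well fall within the scatter. Compound 4 is therefore estimated at 70 nM in this assay, with a range from 25 nM to 200 nM.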

Compound 4, half-maximal inhibitory concentration: 372 nM
Compound 4: middle estimate off by 5.3-fold (0.73 log units), on the low side; measured number outside the range, above it.
By their numbers in this assay, from the lowest: compound 3; then compounds 2, 4 and 1 (each within the scatter of the next, the first and the last beyond it).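

The bicycle on the saturated chain carbon bound to a carbonyl carbon proves sensitive to a single ring atom: in this assay, a nitrogen taking the place of a carbon in the five-membered aromatic ring, with the group still at 9 heavy atoms, gives a 7.9-fold higher number from compound 3 to compound 4 (0.90 log units; beyond the scatter) and shows that the shape of the bicycle alone does not carry the low number. The second new step reads a 1.9-fold higher number from compound 2 to compound 4 (0.29 log units; within the scatter) and so places the two compounds level, which means that among compounds 2, 3 and 4, the two with a five-membered aromatic ring with 2 hetero atoms stand together whichever six-membered aromatic ring they carry, while compound 3, with 1 hetero atom in that ring, stands alone at the low end. No measurement offered here accounts for this step.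

The compounds shown leave open whether the low number of compound 3 would hold with a single phenyl ring in place of the bicycle, or with a nitrile or a methyl group added to its bicycle. They also leave open whether a bicycle with a five-membered ring of three nitrogens would follow compound 4 or go further.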